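Two Methyls for One Methoxy on a Carbonyl Carbon

The source may hold more compounds than are shown below. What is called first, only, known or untested is meant among the compounds shown, and "the series" means these compounds.

Compound 1 `COc1ccc(/C=C/c2cc(OC)cc(OC)c2/C=C/C(=O)c2cccc(OC)c2)cc1`: 6.1 ug/mL
Compound 2 `COc1ccc(/C=C/c2cc(OC)cc(OC)c2/C=C/C(=O)c2ccccc2C)cc1`: 5.9 ug/mL
Compound 3 `COc1ccc(/C=C/c2cc(OC)cc(OC)c2/C=C/C(=O)c2ccc(C)cc2C)cc1`: 0.3 ug/mL

In a functional assay on A549 cells (Homo sapiens) for antiproliferative activity, read by MTT assay, with a stated time of 48 h (a lower number here means a stronger inhibitor, a higher number a weaker inhibitor), compound 1 gives the highest of the three numbers. Its nearest neighbour is compound 2, with a 1.0-fold lower number from compound 1 to compound 2 (0.01 log units; within the scatter), so the two are not separated. Compound 3 lies far away: a 20-fold lower number from compound 1 to compound 3 (1.31 log units; beyond the scatter), and from compound 2 the step is a 20-fold lower number from compound 2 to compound 3 (1.29 log units; beyond the scatter).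

Compound 4 `COc1ccc(/C=C/c2cc(OC)cc(OC)c2/C=C/C(=O)c2ccc(C)c(C)c2)cc1` has not been measured. It differs from compound 1 as follows: 3,4-dimethylphenyl in place of 3-methoxyphenyl on a carbonyl carbon

Within the data shown here, the step that bears most directly on this change is the one from compound 1 to compound 3, where a different dimethylphenyl also replaced 3-methoxyphenyl on the carbonyl carbon and brought a 20-fold lower number from compound 1 to compound 3 (1.31 log units; beyond the scatter). The step from compound 2 to compound 3 shows that adding a methyl on an aromatic carbon gave a 20-fold lower number from compound 2 to compound 3 (1.29 log units; beyond the scatter). Since 3,4-dimethylphenyl is not the same group as 2,4-dimethylphenyl, the same size of step cannot be assumed, but a lower number beyond the scatter is expected in this assay, estimated as a 5.1-fold lower number from compound 1 to compound 4 (0.71 log units; beyond the scatter). Compound 4 is therefore estimated at 1.2 ug/mL, within a range of 0.3 ug/mL to 4.5 ug/mL.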

Compound 4, half-maximal inhibitory concentration: 0.1 ug/mL
For compound 4 the middle estimate is 12-fold (1.08 log units) above the measured one; measured number below the stated range.
By their numbers in this assay, from the lowest: compound 4; then compound 3; then compounds 2 and 1 (each within the scatter of the next).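

Compound 3 had left it unclear whether a large step at this carbonyl carbon belonged to 2,4-dimethylphenyl alone. With 3,4-dimethylphenyl in place of 3-methoxyphenyl in this assay, a second dimethylphenyl group gives a large step (a 61-fold lower number from compound 1 to compound 4 (1.79 log units; beyond the scatter)), and the step from the single-methyl group is of similar size (a 59-fold lower number from compound 2 to compound 4 (1.77 log units; beyond the scatter)). The two dimethylphenyl groups are not equivalent, however, since moving one methyl also separates them (a 3.0-fold lower number from compound 3 to compound 4 (0.48 log units; beyond the scatter)), and no measured evidence accounts for any of these differences.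

The compounds shown leave open what a ring carrying only a 4-methyl group would give, and so whether both methyls of compound 4 are needed. They also say nothing about an amine or a carboxylic acid on this ring.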